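Aryl methyl extended to butyl: expectation for compound 4

The source may report more compounds than this note shows. Statements on the series, on what has been measured and on what is new or still open speak of the compounds shown alone.

Three compounds on the shared core carry different groups on the aryl ring. Compound 1 `CN(C)c1ccc(N2C(=O)NC3(CSC4=C3C(=O)c3ncccc3C4=O)C2=O)cc1` gives 10 nM in a functional assay on MCF7 cells (Homo sapiens) for antiproliferative activity, read by MTT assay, with a stated time of 96 h; a lower number here means a stronger inhibitor, a higher number a weaker inhibitor. Compound 2 `CCN(CC)c1ccc(N2C(=O)NC3(CSC4=C3C(=O)c3ncccc3C4=O)C2=O)cc1` gives 30 nM, so a 3.0-fold higher number from compound 1 to compound 2 (0.48 log units; beyond the scatter). Compound 3 `Cc1ccc(N2C(=O)NC3(CSC4=C3C(=O)c3ncccc3C4=O)C2=O)cc1` gives 2 nM, so a 5.0-fold lower number from compound 1 to compound 3 (0.70 log units; beyond the scatter) and a 15-fold lower number from compound 2 to compound 3 (1.18 log units; beyond the scatter). Compound 3 therefore holds the lowest number of the three, with both other compounds above it by steps beyond the scatter.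

Compound 4 `CCCCc1ccc(N2C(=O)NC3(CSC4=C3C(=O)c3ncccc3C4=O)C2=O)cc1` differs from compound 3 by propyl in place of hydrogen on a saturated chain carbon bound to an aromatic carbon. Going by the values given here, no measured step changes a carbon chain on the aryl ring, so none bears on this change directly. Among the compounds with values here, the only step that enlarges a substituent at this position is a 3.0-fold higher number from compound 1 to compound 2 (0.48 log units; beyond the scatter), where the larger group gave the higher number; it concerns a nitrogen-bound group, so its bearing is weak. The step from dimethylamino to methyl, a 5.0-fold lower number from compound 1 to compound 3 (0.70 log units; beyond the scatter), says nothing about chain length. On this thin ground a small rise in the number is expected for compound 4, a 2.5-fold higher number from compound 3 to compound 4 (0.40 log units; beyond the scatter), likely near the edge of the scatter. Compound 4 is estimated at 5 nM in this assay, in the range 1.5 nM to 15 nM.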

Compound 4, half-maximal inhibitory concentration: 70 nM
Compound 4: the middle estimate sits 14-fold (1.15 log units) below what was measured; measured number above the stated range.
By their numbers in this assay, from the lowest: compound 3; then compound 1; then compound 2; then compound 4.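

In this assay, going by these compounds alone, this position responds strongly to the length of a carbon chain alone: the change from 4-methylphenyl to 4-butylphenyl gives a 35-fold higher number from compound 3 to compound 4 (1.54 log units; beyond the scatter) and is the first step that alters only such a chain. Butyl also lies above both amino-substituted compounds, with a 2.3-fold higher number from compound 2 to compound 4 (0.37 log units; beyond the scatter) and a 7.0-fold higher number from compound 1 to compound 4 (0.85 log units; beyond the scatter), so the two compounds with a plain carbon chain now hold the lowest and the highest of the four numbers, and a carbon chain at this place does not by itself give a low number. Nothing available bears on why the added propyl raises the number.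

The compounds shown leave open whether the number climbs gradually or abruptly from methyl to butyl, which ethyl and propyl in place of the methyl would help to settle. They also leave open whether a longer chain such as hexyl continues the rise, and whether a branched group such as tert-butyl or a butyl chain ending in a hydroxyl behaves like the straight butyl.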